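Benzyl in place of phenyl: a small step expected

This account rests on a few compounds, and the source may have more. Where it says the series, first, only, none or still open, it means among the compounds named here.

Measured in a functional assay on SK-OV-3 cells (Homo sapiens) for inhibition; a higher number here means a weaker inhibitor, a lower number a stronger inhibitor:
Compound 1 `CCCCCOC(=O)Nc1nc(=O)n(C2O[C@H](C(=O)O)[C@@H](O)[C@H]2O)cc1F`: 0.03 ug/mL
Compound 2 `O=C(Nc1nc(=O)n(C2O[C@H](C(=O)O)[C@@H](O)[C@H]2O)cc1F)Oc1ccccc1`: 0.12 ug/mL

Compound 2 holds the higher of the two numbers, which makes it the weaker inhibitor of this pair. Going by the values given here, the only measured step is a 4.0-fold higher number from compound 1 to compound 2 (0.60 log units; beyond the scatter), and it replaced pentyl with phenyl at the same place that changes next. Compound 3 `O=C(Nc1nc(=O)n(C2O[C@H](C(=O)O)[C@@H](O)[C@H]2O)cc1F)OCc1ccccc1` carries benzyl in place of phenyl on an oxygen next to a carbonyl group. Among the compounds with values here, that single step is the only guide, and it sets a modest scale for changes at this oxygen. Compound 3 is therefore expected to fall between the two measured compounds, nearer the lower number of this assay than compound 2 but not past compound 1. The expected step is a 1.7-fold lower number from compound 2 to compound 3 (0.23 log units; within the scatter), which may not clear the scatter. For compound 3 the estimated value is 0.07 ug/mL, with an expected range from 0.025 ug/mL to 0.2 ug/mL.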

Compound 3, half-maximal inhibitory concentration: 0.07 ug/mL
Compound 3: middle estimate and measured number agree at the digits printed; measured number inside the range.
By their numbers in this assay, from the lowest: compound 1; then compounds 3 and 2 (each within the scatter of the next).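

In this assay, the phenoxy to benzyloxy change does not separate the two groups on this oxygen: the result is a 1.7-fold lower number from compound 2 to compound 3 (0.23 log units; within the scatter). The pentyl group of compound 1 does stand apart from the benzyl group, with a 2.3-fold higher number from compound 1 to compound 3 (0.37 log units; beyond the scatter), so with the earlier step both groups carrying an aromatic ring now sit on the weaker side of pentyl, and placing the ring further out does not close that gap beyond the scatter. Nothing available on these compounds accounts for either step.

The compounds shown leave open how a chain longer than pentyl, or a shorter one such as propyl, would read at this oxygen. They also leave open whether an amine or a carboxylic acid at the end of the chain would move the number at all.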